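The compounds below may be only part of what the source reports. "The series", "measured", "known", "first", "only" and "open" are said of these compounds alone.

Measured in an assay on HEK293 cells for agonist activity at Toll-like receptor 8 (Homo sapiens), read by a luciferase reporter, with a stated time of 6 h; on this read-out higher numbers stand for an effect only at larger amounts of compound and lower numbers for an effect already at smaller amounts:
compound 1 `CCCCNc1nc(N)nc2c1CCN(C)C2` — 0.2 uM
compound 2 `CCCCNc1nc(N)nc2c1CN(C(C)=O)CC2` — 0.5 uM
compound 3 `CCCCNc1nc(N)nc2c1CN(S(C)(=O)=O)CC2` — 9.9 uM

Compound 1 stands lowest of the three numbers, below compound 2 and well below compound 3. Compound 4 `CCCCNc1nc(N)nc2c1CCN(S(C)(=O)=O)C2` is not yet measured; its change from compound 1 is methylsulfonyl in place of methyl on an amine nitrogen in a ring. For the measured compounds named here, the one measured step that bears on this is a 20-fold higher number from compound 2 to compound 3 (1.30 log units; beyond the scatter), which introduces the same methylsulfonyl group on the ring nitrogen, though starting from acetyl rather than from methyl. Going by the values given here, no step from methyl directly to methylsulfonyl has been measured. On that basis a large rise in the number in this assay is expected for compound 4, a 25-fold higher number from compound 1 to compound 4 (1.40 log units; beyond the scatter). Compound 4 is estimated at 5 uM, within a range from 1.5 uM to 20 uM.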

Compound 4, minimum effective concentration: 0.8 uM
The estimate for compound 4 lay 6.3-fold (0.80 log units) above the measured number; measured number below the stated range.
By their numbers in this assay, from the lowest: compound 1; then compounds 2 and 4 (each within the scatter of the next); then compound 3.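

In this assay methylsulfonyl in place of methyl on this amine nitrogen brings only a modest step (a 4.0-fold higher number from compound 1 to compound 4 (0.60 log units; beyond the scatter)). The same group on the ring nitrogen of compound 3 came with a large step (a 20-fold higher number from compound 2 to compound 3 (1.30 log units; beyond the scatter)), but it replaced acetyl there and the nitrogen stands at a different place in the core, so a large rise does not follow from methylsulfonyl alone. Nothing at hand gives a cause for this contrast.

Open, as far as these compounds go, is whether the size of the step follows the group replaced or the place of the nitrogen; acetyl on the nitrogen of the core of compound 1 would separate the two. Also open, from the compounds shown here alone, is how ethylsulfonyl or a free ring amine would read at this nitrogen.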